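The compounds below may be only part of what the source reports. "The series", "measured", "known", "first", "only" and "open" are said of these compounds alone.

Compound 1, `COc1ccc(/C=C/C(=O)c2cc(OC)c(OC)c(OC)c2)cc1OCCCC(=O)NCCCCN(CCCN)CCCCN`, is measured in a functional assay on DU-145 cells (Homo sapiens) for antiproliferative activity, read by MTT assay, with a stated time of 48 h (a lower number here means a stronger inhibitor, a higher number a weaker inhibitor), at 82300 nM. Among the two plain numbers given here it stands lowest, yet compound 3, `COc1cc(C(=O)/C=C/c2ccc(OCCCC(=O)NCCCCN(CCCN)CCCCNCCCN)cc2)cc(OC)c1OC`, gives 92500 nM in this assay, a value within the scatter of compound 1. Compound 2, `COc1ccc(/C=C/C(=O)c2cc(OC)c(OC)c(OC)c2)cc1OCCCC(=O)NCCCNCCCCN`, returns in this assay only a limit, > 100000 nM. Within the data shown here, the single step that can be read from the measured compounds is an at least 1.2-fold higher number from compound 1 to compound 2 (0.08 log units; that floor lies within the scatter); it rests on the limit of > 100000 nM in this assay, at which 1 of the 3 values shown sits, and its size is therefore only a floor.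

Compound 4, `COc1ccc(/C=C/C(=O)c2cc(OC)c(OC)c(OC)c2)cc1OCCCC(=O)NCCCCN(CCCN)CCCCNCCCN`, differs from compound 1 by 3-aminopropyl in place of hydrogen on an amine nitrogen. Among the measured compounds shown here, no measured step adds a 3-aminopropyl group to an amine nitrogen. The nearest guidance comes from compound 3, which carries the same chain on a core unlike that of compound 1; in this assay compound 3 gives 92500 nM. On that basis a step from compound 1 to compound 4 within the scatter is expected, a 1.1-fold higher number from compound 1 to compound 4 (0.04 log units; within the scatter). Compound 4 is accordingly estimated at 90000 nM in this assay, with a range from 45000 nM to 180000 nM.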

Compound 4, half-maximal inhibitory concentration: 84900 nM
The estimate for compound 4 lay 1.1-fold (0.03 log units) above the measured number, within the range that was stated.
By their numbers in this assay, from the lowest: compounds 1, 4 and 3 (each within the scatter of the next). At a limit, above all of these: compound 2.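

At this amine nitrogen, whose other neighbours are saturated chain carbon, 3-aminopropyl in place of hydrogen gives a 1.0-fold higher number from compound 1 to compound 4 (0.01 log units; within the scatter) in this assay. Among these compounds, this is the first measured step for this change on the shared core; before it, the same chain had been seen only in compound 3, on a core unlike that of compound 1. Nothing given here bears on why this step is so small.

As far as these compounds go, it stays open whether a carboxylic acid, an acetyl group or a shorter chain on this same nitrogen would move the number beyond the scatter. From the compounds shown here alone, it also stays open whether removing 3-aminopropyl from the core of compound 3 would give an equally small step.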